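The source may hold more compounds than are shown below. What is called first, only, known or untested is meant among the compounds shown, and "the series" means these compounds.

Measured in a functional assay on HT-29 cells (Homo sapiens) for inhibition, with a stated time of 72 h; on this read-out lower numbers stand for stronger inhibition and higher numbers for weaker inhibition:
- compound 1 `COc1ccc(S(=O)(=O)N2CCc3cccc(-c4ccc(F)cc4)c32)cc1`: 85.5 nM
- compound 2 `COc1ccc(S(=O)(=O)n2ccc3cccc(-c4ccc(C#N)cc4)c32)cc1`: 164 nM

Not yet measured:
- compound 3 `COc1ccc(S(=O)(=O)N2CCc3cccc(-c4ccc(C#N)cc4)c32)cc1`

In this assay, compound 1 at 85.5 nM cannot be separated from compound 2 at 164 nM, as the gap between them lies within the usual scatter. Compound 3 keeps the core of compound 1 and carries cyano in place of fluoro on an aromatic carbon, para to a large group, turning 4-fluorophenyl into 4-cyanophenyl (cyano in place of fluoro on an aromatic carbon). For the measured compounds named here, no measured pair isolates this change. Going by the values given here, the only guide is compound 2, which gives 164 nM and carries the 4-cyanophenyl group on a core other than that of compound 1. A small move towards a higher number is therefore expected, possibly no larger than the scatter, and the estimated step of a 1.4-fold higher number from compound 1 to compound 3 (0.15 log units; within the scatter) reflects this. For compound 3, the expected value is 120 nM, with an estimated range of 50 nM to 300 nM.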

Compound 3, half-maximal inhibitory concentration: 24.2 nM
The estimate for compound 3 lay 5.0-fold (0.70 log units) above the measured number, and the stated range ends above it.
By their numbers in this assay, from the lowest: compound 3; then compounds 1 and 2 (each within the scatter of the next).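

In this assay, the swap from 4-fluorophenyl to 4-cyanophenyl on the core of compound 1 gives a 3.5-fold lower number from compound 1 to compound 3 (0.55 log units; beyond the scatter), so this place, para to a large group, responds to the change by more than the scatter. The 4-cyanophenyl group does not settle the number by itself, since compound 2 on its other core reads 164 nM, while compound 3 reads 24.2 nM. No measurement at hand explains why the nitrile outdoes the fluoro here.

The compounds shown leave open whether the same swap would give a similar step on the core of compound 2. They also leave open how chloro, methoxy, an amine or a carboxylic acid would read at this same place.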